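Three Level Readings Before a Trimethoxyphenyl Swap

The source may hold more compounds than are shown below. What is called first, only, known or untested is meant among the compounds shown, and "the series" means these compounds.

Compound 1, `Cc1cc(O)c(C2=NN(c3ccc(S(N)(=O)=O)cc3)C(c3ccccc3Cl)C2)cc1Cl`, gives 71.4%.
Compound 2, `Cc1cc(O)c(C2=NN(c3ccc(S(N)(=O)=O)cc3)C(c3ccc(Cl)cc3)C2)cc1Cl`, gives 71.4%.
Compound 3, `Cc1cc(O)c(C2=NN(c3ccc(S(N)(=O)=O)cc3)C(/C=C/c3ccccc3)C2)cc1Cl`, gives 71.4%.

These three values come from a functional assay on the whole organism (strain Wistar) for inhibition, with Rattus norvegicus as the target, read by paw edema, with stated times of 30 min and 5 h, at a dose of 20 mg/kg by the oral route; a higher number here means more inhibition at the dose given (going by the name of the read-out), a lower number less inhibition. Compound 3 stands level with compounds 1 and 2; the three share one core and differ only in the group on a saturated ring carbon, yet the read-outs do not separate. The step of no change at the digits printed from compound 1 to compound 2 (within the scatter) shows this, as does no change at the digits printed from compound 1 to compound 3 (within the scatter) and no change at the digits printed from compound 2 to compound 3 (within the scatter).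

Compound 4, `COc1ccc(C2CC(c3cc(Cl)c(C)cc3O)=NN2c2ccc(S(N)(=O)=O)cc2)c(OC)c1OC`, has not yet been measured. It differs from compound 3 by 2,3,4-trimethoxyphenyl in place of 2-phenylethenyl on a saturated ring carbon.

All three measured steps bear on this change, since each exchanged the group on the same saturated ring carbon, and each lay within the scatter. The new group, 2,3,4-trimethoxyphenyl, brings three hydrogen-bond acceptors that none of the earlier groups carried, so the measured steps do not cover it fully; still, nothing seen so far points in either direction. The expected step of a number 1.4 percentage points lower from compound 3 to compound 4 (within the scatter) is therefore estimated as none beyond the scatter. Compound 4 is expected to give about 70%, with an estimated range from 55% to 82%.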

Compound 4, a percentage reported as inhibition, in the whole organism at one dose (the size of the read-out at that dose, not a potency): 88.1%
Compound 4: middle estimate off by 18.1 percentage points, on the low side; the measured number lies above the stated range.
By their numbers in this assay, from the lowest: compounds 1, 2 and 3 (each within the scatter of the next); then compound 4.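

The group on this saturated ring carbon can move the read-out after all: in this assay the exchange for 2,3,4-trimethoxyphenyl reads a number 16.7 percentage points higher from compound 3 to compound 4 (beyond the scatter) when it replaces 2-phenylethenyl, a number 16.7 percentage points higher from compound 2 to compound 4 (beyond the scatter) when it replaces 4-chlorophenyl, and a number 16.7 percentage points higher from compound 1 to compound 4 (beyond the scatter) when it replaces 2-chlorophenyl. The level readings of the earlier compounds therefore showed only that those three groups do not separate from one another, not that this position is indifferent to what it carries, and among these four compounds the only group with hydrogen-bond acceptors is also the one that stands apart. Nothing measured here explains the higher number, so that match remains an observation from a single compound.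

Going by these compounds, it remains open whether the whole 2,3,4-trimethoxyphenyl group is needed, or whether a phenyl ring with a single methoxy group would do as well. On these data alone, the effect of a different kind of group on this carbon, such as a pyridine ring or a dimethylamino group, also remains unknown.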